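The compounds below may be only part of what the source reports. "The series", "measured", "known", "first", "only" and "open" are said of these compounds alone.

Measured so far in a functional assay on NCI/ADR-RES cells (Homo sapiens) for inhibition, read by sulforhodamine B assay, with a stated time of 48 h; on this read-out higher numbers stand for weaker inhibition of growth and lower numbers for stronger inhibition of growth:
- compound 1 `CCOC(=O)C1=C(C)NC(=O)NC1c1ccc(O)c(O)c1`: 2.1 ug/mL
- compound 2 `CCCc1ccc(C2NC(=O)NC(C)=C2C(=O)OCC)cc1`: 20.9 ug/mL

Compound 2, at 20.9 ug/mL, holds the higher of the two numbers and so shows the weaker inhibition of growth. The gap down to compound 1, at 2.1 ug/mL, lies beyond the scatter.

The next compound to be read is compound 3 `CCOC(=O)C1=C(C)NC(=O)NC1c1ccc(O)cc1`, which has hydroxy in place of propyl on an aromatic carbon, para to a large group (hydroxy in place of propyl on an aromatic carbon).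

Among the compounds with values here, no measured pair differs in one place only, so the two values give no direct size for this change in this assay. Within the data shown here, the only guide is that compound 1, which also carries hydroxy on its aromatic ring, gives 2.1 ug/mL. With a single compound behind it, this supports only a loose expectation of a lower number for compound 3, probably beyond the scatter, though not as low as that of compound 1.

The expected change is a 3.0-fold lower number from compound 2 to compound 3 (0.48 log units; beyond the scatter), toward stronger inhibition of growth.

Compound 3 is estimated at 7 ug/mL, with an expected range of 2 ug/mL to 22 ug/mL.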

Compound 3, concentration for 50% growth inhibition: 3.2 ug/mL
The estimate for compound 3 lay 2.2-fold (0.34 log units) above the measured number; measured number inside the range.
By their numbers in this assay, from the lowest: compounds 1 and 3 (each within the scatter of the next); then compound 2.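

In this assay, hydroxy in place of propyl on an aromatic carbon, para to a large group, gives a 6.5-fold lower number from compound 2 to compound 3 (0.81 log units; beyond the scatter), toward stronger inhibition of growth, and this puts a direct size on a change that the first two compounds could only hint at. The further hydroxy of compound 1 is not needed to hold this level of inhibition: hydrogen in its place gives a 1.5-fold higher number from compound 1 to compound 3 (0.18 log units; within the scatter), which leaves compound 1 and compound 3 indistinguishable in this assay, so on these compounds the large step belongs to the exchange of propyl for hydroxy and not to the number of hydroxy groups. No supporting data speak to the reason for either step.

Still open, as far as these compounds go, is whether hydroxy itself is required at this place, or whether an amine or a methoxy on the same aromatic carbon would serve as well, and whether an unsubstituted ring would sit nearer to compound 2 or to compound 3, which would show how much of the step comes from losing propyl and how much from gaining hydroxy. From the compounds shown here alone, all three compounds also carry the same ethyl ester, so the contribution of that group stays unknown, and a carboxylic acid in its place would begin to address it.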